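This account rests on a few compounds, and the source may have more. Where it says the series, first, only, none or still open, it means among the compounds named here.

Compound 1, `Cc1cc(CO)nc(NNC(=O)Nc2cc(Cl)nc(Cl)c2)c1`, is one of three compounds tested in a functional assay on CHO cells for agonist activity at sphingosine 1-phosphate receptor 2 (Homo sapiens), read by fluorescence and calcium flux, with a stated time of 3 min; a lower number here means a stronger inhibitor, a higher number a weaker inhibitor. In this assay compound 1 gives > 23000 nM, which is a limit of the assay rather than a number. Compound 2, `Cc1cc(NNC(=O)Nc2cc(Cl)nc(Cl)c2)ncc1-c1cnn(C)c1`, gives > 23000 nM in this assay, also a limit. Compound 3, `Cc1cc(NNC(=O)Nc2cc(Cl)nc(Cl)c2)ncc1-c1cn(C)nc1C`, gives > 23000 nM in this assay, again a limit. Within the data shown here, the only step between compounds that differ in a single place, a step that the two limits leave unreadable from compound 2 to compound 3, cannot be read because of the limit of > 23000 nM in this assay, at which 3 of the 3 values shown sit. Compound 4, `Cc1cc(NNC(=O)Nc2cc(Cl)nc(Cl)c2)nc(C(=O)N(C)C)c1`, has not yet been measured; it differs from compound 1 by dimethylcarbamoyl in place of hydroxymethyl on an aromatic carbon. Among the measured compounds shown here, no measured step bears directly on this change, and the single step that exists has no readable size. Compound 4 is therefore expected to sit near the limit as well, with an estimated value of 30000 nM, between 10000 nM and 100000 nM. The step that the limit leaves unreadable from compound 1 to compound 4 is expected to be none beyond the scatter.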

Compound 4, half-maximal inhibitory concentration: > 23000 nM
Compound 4: a limit, no number; the forecaster's own chance of this, stated with the estimate: 85%; the middle value does not contradict the limit.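

No step can be read between compound 1 and compound 4, or between any other pair shown, because every result is a limit and not a number: the limit of > 23000 nM in this assay, at which 4 of the 4 values shown sit.

What the compounds shown leave open is how strongly any of them acts in this assay, and which change on the shared core would shift that.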